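The source may report more compounds than this note shows. Statements on the series, on what has been measured and on what is new or still open speak of the compounds shown alone.

Values in a functional assay on Huh-5-2 cells (Homo sapiens) for cytotoxicity, read by microscopy; on this read-out lower numbers stand for higher toxicity in this test and higher numbers for lower toxicity in this test:
- compound 1 `CC(=O)OC[C@H]1O[C@@H](n2c(SCc3cc4ccccc4oc3=O)nc3cncnc32)[C@H](O)[C@@H]1O`: 8700 nM
- compound 2 `CC(=O)OC[C@H]1O[C@@H](n2c(SCc3cc4cc(F)ccc4oc3=O)nc3cncnc32)[C@H](O)[C@@H]1O`: 8600 nM
- compound 3 `O=c1oc2ccccc2cc1CSc1nc2cncnc2n1[C@@H]1O[C@H](CO)[C@@H](O)[C@H]1O`: 50000 nM

Compound 3 has the highest number of the three at 50000 nM, so it is the least toxic in this assay. Compounds 1 and 2 both sit well under it, and the values of those two lie within the scatter of each other.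

The next compound to consider is compound 4 `O=c1oc2ccc(F)cc2cc1CSc1nc2cncnc2n1[C@@H]1O[C@H](CO)[C@@H](O)[C@H]1O`, which is compound 3 with one change: fluoro in place of hydrogen on an aromatic carbon. In words, this is fluoro in place of hydrogen on an aromatic carbon.

One measured step makes this same exchange, starting from compound 1. That step is a 1.0-fold lower number from compound 1 to compound 2 (0.01 log units; within the scatter), so the exchange left the number essentially unmoved there. The other measured step is a 5.7-fold higher number from compound 1 to compound 3 (0.76 log units; beyond the scatter). It shows that the acetyl group matters to this number, and compound 3 lacks that acetyl. Within the data shown here, no measurement yet tests the fluoro exchange without the acetyl, so the expectation rests on a single pair and carries real uncertainty.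

The expected step is small, within the scatter and with no clear direction: no change at the digits printed from compound 3 to compound 4 (within the scatter). Compound 4 is estimated at 50000 nM, with an expected range of 22000 nM to 100000 nM.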

Compound 4, half-maximal cytotoxic concentration: 36000 nM
For compound 4 the middle estimate is 1.4-fold (0.14 log units) above the measured one; low and high end bracket the measured number.
By their numbers in this assay, from the lowest: compounds 2 and 1 (each within the scatter of the next); then compounds 4 and 3 (each within the scatter of the next).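

Among these compounds, compound 4 gives the first reading of the fluoro exchange on the core without the acetyl. In this assay the result is a 1.4-fold lower number from compound 3 to compound 4 (0.14 log units; within the scatter), so at this aromatic carbon fluoro in place of hydrogen stays within the scatter with or without the acetyl, and the two readings agree: the same change on two cores in this assay, a 1.0-fold lower number (0.01 log units; within the scatter) from compound 1 to compound 2 and a 1.4-fold lower number (0.14 log units; within the scatter) from compound 3 to compound 4, 1.4-fold (0.14 log units) apart, within the scatter of two such steps

Compound 4 also gives a second reading of the acetyl change, this time with fluoro present, as a 4.2-fold higher number from compound 2 to compound 4 (0.62 log units; beyond the scatter). Swapping acetyl for hydrogen on the oxygen therefore gives a higher number, meaning lower toxicity in this test, on both the fluoro and the non-fluoro cores, and the two steps match: the same change on two cores in this assay, a 5.7-fold higher number (0.76 log units; beyond the scatter) from compound 1 to compound 3 and a 4.2-fold higher number (0.62 log units; beyond the scatter) from compound 2 to compound 4, 1.4-fold (0.14 log units) apart, within the scatter of two such steps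

Fluoro is the only replacement for hydrogen shown on this ring, so it remains open whether chloro, methoxy or an amine at the same carbon would also leave the number in place. On these data alone, it is equally open whether a longer ester chain, such as butyryl, in place of acetyl on that oxygen would give a number nearer to those of the acetyl compounds or to those of the compounds with a free hydroxyl.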